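The source may report more compounds than this note shows. Statements on the series, on what has been measured and on what is new or still open speak of the compounds shown alone.

In a functional assay on MCF7 cells (Homo sapiens) for inhibition, read by MTT assay, with a stated time of 72 h (on this read-out higher numbers stand for weaker inhibition and lower numbers for stronger inhibition), compound 1 (`Cc1cc(Nc2cc(-c3cccs3)[nH]n2)n2nc(SCc3ccc(Br)cc3)nc2n1`) gives 5370 nM and compound 2 (`Cc1cc(Nc2cc(-c3ccccc3)[nH]n2)n2nc(SCC(=O)c3ccccc3)nc2n1`) gives 5240 nM while compound 3 (`Cc1cc(Nc2ccn(Cc3ccc(F)cc3)n2)n2nc(SCc3ccc(Br)cc3)nc2n1`) gives 4280 nM on the same read-out. Compound 2 lies within the usual scatter of both other compounds, so these three numbers cannot be told apart. The three structures also differ from one another in more than one place, so no single structural change can be read from them.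

The next compound to be tested is compound 4 (`Cc1cc(Nc2cc(-c3ccccc3)[nH]n2)n2nc(SCc3nc4ccccc4[nH]3)nc2n1`), which differs from compound 2 in one place only: 1H-benzimidazol-2-yl stands in place of benzoyl on a saturated chain carbon bound to a sulfur (1H-benzimidazol-2-yl in place of benzoyl on a saturated chain carbon bound to a sulfur). Going by the values given here, no measured pair shows what this swap does. Among the compounds with values here, the only guide is that compound 1 at 5370 nM and compound 3 at 4280 nM stay within the scatter of compound 2 despite carrying different groups. In this assay no change beyond the scatter is therefore expected, and any direction is tentative. The expected step of a 1.3-fold lower number from compound 2 to compound 4 (0.12 log units; within the scatter) is slight and leans toward stronger inhibition. Compound 4 is estimated at 4000 nM with an expected range from 1500 nM to 10000 nM when it is measured.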

Compound 4, half-maximal inhibitory concentration: 2730 nM
The estimate for compound 4 lay 1.5-fold (0.17 log units) above the measured number, and the stated range covers the measured number.
By their numbers in this assay, from the lowest: compounds 4, 3, 2 and 1 (each within the scatter of the next).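

In this assay, going by these compounds alone, the step of a 1.9-fold lower number from compound 2 to compound 4 (0.28 log units; within the scatter) is the first comparison in this set that alters a single place, the group on a saturated chain carbon bound to a sulfur. The swap takes away benzoyl with its carbonyl and brings in 1H-benzimidazol-2-yl, which has a five-membered aromatic ring with two nitrogens and a hydrogen-bond donor, yet the two compounds cannot be told apart on this read-out. This position therefore accepts two quite different groups with no change beyond the scatter, and no measurement of any property of these groups is available to interpret that result.

The compounds shown leave open whether a different kind of group at this position, such as a simple amine, a carboxylic acid or a longer carbon chain, would move the number beyond the scatter. A single pair also cannot show whether the same swap would read alike in compounds that carry other groups elsewhere on the shared core, such as the thiophene-bearing compound 1.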